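Pyrimidinedione sultone series: urea variant for the cytotoxicity assay

The source may hold more compounds than are shown below. What is called first, only, known or untested is meant among the compounds shown, and "the series" means these compounds.

Measured so far:
compound 1, `Cc1cn([C@@H]2O[C@H](CO[Si](C)(C)C(C)(C)C)[C@@]3(OS(=O)(=O)C=C3NCCC(=O)O)[C@H]2O[Si](C)(C)C(C)(C)C)c(=O)n(C)c1=O`, 19400 nM
compound 2, `CCOC(=O)CNC(=O)NC1=CS(=O)(=O)O[C@@]12[C@@H](CO[Si](C)(C)C(C)(C)C)O[C@@H](n1cc(C)c(=O)n(C)c1=O)[C@@H]2O[Si](C)(C)C(C)(C)C`, 5020 nM
compound 3, `Cc1cn([C@@H]2O[C@H](CO[Si](C)(C)C(C)(C)C)[C@@]3(OS(=O)(=O)C=C3NCC(=O)C(N)=O)[C@H]2O[Si](C)(C)C(C)(C)C)c(=O)n(C)c1=O`, 9960 nM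

In a functional assay on CCRF-CEM cells (Homo sapiens) (a lower number here means that less compound is tolerated, a higher number that more compound is tolerated), compound 3 gives 9960 nM, the second highest of the three numbers. Its nearest neighbour is compound 1, a 1.9-fold lower number from compound 1 to compound 3 (0.29 log units; within the scatter); furthest is compound 2, a 2.0-fold higher number from compound 2 to compound 3 (0.30 log units; within the scatter). Neither gap is beyond the scatter, so the three cannot be ordered with confidence.

Compound 4, `C=C(C)C(=O)NC(=O)NC1=CS(=O)(=O)O[C@@]12[C@@H](CO[Si](C)(C)C(C)(C)C)O[C@@H](n1cc(C)c(=O)n(C)c1=O)[C@@H]2O[Si](C)(C)C(C)(C)C`, is not yet measured. It differs from compound 3 in one place: ((1-methylethenyl)carbonyl)carbamoyl in place of (carbamoylcarbonyl)methyl on an amine nitrogen. The entering group is a carbamoyl on the amine nitrogen, which is the same kind of substitution that compound 2 carries. Going by the values given here, the one step that bears on this is a 3.9-fold lower number from compound 1 to compound 2 (0.59 log units; beyond the scatter), where a carbamoyl replaced a chain substituent on the same nitrogen and gave a modest drop in this assay. Compound 3 itself sits close to compound 1, a 1.9-fold lower number from compound 1 to compound 3 (0.29 log units; within the scatter).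

Compound 4 is therefore expected to move toward the number of compound 2, an estimated 1.7-fold lower number from compound 3 to compound 4 (0.22 log units; within the scatter). The estimate for compound 4 is 6000 nM, with a range from 2500 nM to 15000 nM.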

Compound 4, half-maximal cytotoxic concentration: 1200 nM
Compound 4: middle estimate off by 5.0-fold (0.70 log units), on the high side; the measured number lies below the stated range.
By their numbers in this assay, from the lowest: compound 4; then compounds 2, 3 and 1 (each within the scatter of the next, the first and the last beyond it).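

In this assay, the group on the amine nitrogen matters more than compound 1, compound 2 and compound 3 could show: ((1-methylethenyl)carbonyl)carbamoyl gives an 8.3-fold lower number from compound 3 to compound 4 (0.92 log units; beyond the scatter) and a 16-fold lower number from compound 1 to compound 4 (1.21 log units; beyond the scatter), the largest step in the series. Compound 2 and compound 4 both carry a carbamoyl on this nitrogen, yet (1-methylethenyl)carbonyl in place of (ethoxycarbonyl)methyl on the amide-type nitrogen gives a 4.2-fold lower number from compound 2 to compound 4 (0.62 log units; beyond the scatter). The carbamoyl alone therefore does not set the number; the group on the amide-type nitrogen also counts.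

No data at hand speak to the reason for these steps. Open, as far as these compounds go, is whether the double bond of the 1-methylethenyl group is needed for the lower number, a question that a saturated 2-methylpropanoyl group on the same amide-type nitrogen would address.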